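The source may hold more compounds than are shown below. What is called first, only, known or untested is meant among the compounds shown, and "the series" means these compounds.

In a functional assay on MGC-803 cells (Homo sapiens) for inhibition, read by MTT assay, with a stated time of 72 h (a lower number here means a stronger inhibitor, a higher number a weaker inhibitor), compound 3 `Cc1csc(Sc2cc(C(F)(F)F)nc(SCc3ccc(C(F)(F)F)cc3)n2)n1` gives 21300 nM, within the scatter of compound 1 `FC(F)(F)c1ccc(CSc2nc(N3CCN(c4ccccn4)CC3)cc(C(F)(F)F)n2)cc1` at 23500 nM and of compound 2 `FC(F)(F)c1ccc(CSc2nc(N3CCN(c4ncccn4)CC3)cc(C(F)(F)F)n2)cc1` at 35200 nM. Compound 4 `FC(F)(F)c1ccc(CSc2nc(SC3=NCCS3)cc(C(F)(F)F)n2)cc1` differs from compound 3 by a group of 5 heavy atoms (3 carbon, 1 nitrogen, 1 sulfur; one five-membered non-aromatic ring with 2 hetero atoms) in place of a group of 6 heavy atoms (4 carbon, 1 nitrogen, 1 sulfur; one five-membered aromatic ring with 2 hetero atoms), on a sulfur. Among the compounds with values here, no measured step covers this change. Within the data shown here, the only step available, a 1.5-fold higher number from compound 1 to compound 2 (0.18 log units; within the scatter), exchanges a different ring elsewhere on the core and bears on it only loosely, showing one ring exchange that stayed within the scatter. No step beyond the scatter is therefore expected in this assay, and no direction is favoured: the expected step is a 1.2-fold higher number from compound 3 to compound 4 (0.07 log units; within the scatter). For compound 4 the estimated value is 25000 nM, with an expected range of 12000 nM to 50000 nM.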

Compound 4, half-maximal inhibitory concentration: 24500 nM
The estimate for compound 4 lay 1.0-fold (0.01 log units) above the measured number; low and high end bracket the measured number.
By their numbers in this assay, from the lowest: compounds 3, 1, 4 and 2 (each within the scatter of the next).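

In this assay, within the data shown here, exchanging 4-methyl-1,3-thiazol-2-yl for the non-aromatic five-membered ring on a sulfur whose other neighbour is an aromatic carbon gives a 1.2-fold higher number from compound 3 to compound 4 (0.06 log units; within the scatter), the only step read at this place. For this pair, the number stays within the scatter without an aromatic ring on that sulfur. Nothing available bears on why the number holds across this change. Going by these compounds, whether a carboxylic acid or a longer alkyl chain on this sulfur would give a step beyond the scatter stays open.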